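Swapping 1-amino-2-methylpropyl for 1-hydroxyethyl on a carbonyl carbon

This account rests on a few compounds, and the source may have more. Where it says the series, first, only, none or still open, it means among the compounds named here.

Compounds measured so far in a functional assay on U-87MG ATCC cells (Homo sapiens) for antiproliferative activity; on this read-out lower numbers stand for stronger inhibition and higher numbers for weaker inhibition
- compound 1 `Cc1c2c(n3c1CCN(C)C[C@@H](C)[C@H](C)Nc1cc-3ccc1C(N)=O)CC(C)(C)CC2=O` gives 49 nM
- compound 2 `CC(=O)N1CCc2c(C)c3c(n2-c2ccc(C(N)=O)c(c2)N[C@@H](C)[C@H](C)C1)CC(C)(C)CC3=O` gives 24 nM
- compound 3 `Cc1c2c(n3c1CCN(C(=O)[C@@H](N)C(C)C)C[C@@H](C)[C@H](C)Nc1cc-3ccc1C(N)=O)CC(C)(C)CC2=O` gives 48 nM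

Compound 3 stands within the scatter of both other compounds, as a 1.0-fold lower number from compound 1 to compound 3 (0.01 log units; within the scatter) shows. Compound 4 `Cc1c2c(n3c1CCN(C(=O)[C@H](C)O)C[C@@H](C)[C@H](C)Nc1cc-3ccc1C(N)=O)CC(C)(C)CC2=O` differs from it in one place, with 1-hydroxyethyl in place of 1-amino-2-methylpropyl on a carbonyl carbon. The closest evidence is a change of group on that same carbonyl carbon, which gave a 2.0-fold higher number from compound 2 to compound 3 (0.30 log units; within the scatter) and so stayed within the scatter. Among the compounds with values here, the only step beyond the scatter is modest, namely a 2.0-fold lower number from compound 1 to compound 2 (0.31 log units; beyond the scatter). All three compounds thus span a narrow range in this assay, and no large shift is expected here. The expected step is a 1.3-fold lower number from compound 3 to compound 4 (0.12 log units; within the scatter) and so none beyond the scatter. The estimate for compound 4 is 36 nM. The expected range for compound 4 runs from 15 nM to 85 nM, and the measurement will show whether it holds.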

Compound 4, half-maximal inhibitory concentration: 88 nM
Compound 4: the middle estimate sits 2.4-fold (0.39 log units) below what was measured; measured number outside the range, above it.
By their numbers in this assay, from the lowest: compounds 2, 3, 1 and 4 (each within the scatter of the next, the first and the last beyond it).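

In this assay, replacing 1-amino-2-methylpropyl with 1-hydroxyethyl on this carbonyl carbon stays within the scatter (a 1.8-fold higher number from compound 3 to compound 4 (0.26 log units; within the scatter)), and so does replacing the methyl on the ring nitrogen with (1-hydroxyethyl)carbonyl (a 1.8-fold higher number from compound 1 to compound 4 (0.25 log units; within the scatter)). What is new is that a change of group on this carbonyl carbon now goes beyond the scatter: 1-hydroxyethyl in place of methyl gives a modest step (a 3.7-fold higher number from compound 2 to compound 4 (0.56 log units; beyond the scatter)), whereas 1-amino-2-methylpropyl in place of methyl stayed within it. Nothing at hand explains this difference between the two groups.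

The compounds shown leave open whether these numbers follow the amine or the branched chain, as 1-amino-2-methylpropyl and 1-hydroxyethyl differ in both, and a 1-aminoethyl group on the same carbonyl carbon would separate the two. They also leave open where a carboxylic acid or a longer chain at this position would fall.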